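This account rests on a few compounds, and the source may have more. Where it says the series, first, only, none or still open, it means among the compounds named here.

Measured compounds:
compound 1 `O=C(Nc1cccc(-n2cc(-c3ccncc3)c(-c3cc(O)cc(Cl)c3)n2)c1)Nc1ccc(Cl)c(C(F)(F)F)c1` gives 34.6%
compound 2 `COc1cc(Cl)cc(-c2nn(-c3cccc(NC(=O)c4cccc(C(F)(F)F)c4)c3)cc2-c2ccncc2)c1` gives 65.9%
compound 3 `O=C(Nc1cccc(-n2cc(-c3ccncc3)c(-c3cc(O)cc(Cl)c3)n2)c1)c1cc(C(F)(F)F)cc(C(F)(F)F)c1` gives 50.3%

These three compounds were compared in a functional assay on SN12C cells (Homo sapiens) for inhibition, read by sulforhodamine B assay, with a stated time of 48 h, tested at 10 uM; a higher number here means a weaker effect of the compound at the concentration tested, a lower number a stronger effect. Among the three numbers, compound 3 stands second highest. Its nearest neighbour is compound 2, whose number lies higher by more than the scatter, and the compound furthest from it is compound 1, whose number lies lower by more than the scatter. For the measured compounds named here, compound 2 and compound 3 differ in more than one place, so their two values show only that compound 2 gave the higher, weaker reading in this assay.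

The next compound, compound 4 `COc1cc(Cl)cc(-c2nn(-c3cccc(NC(=O)c4cc(C(F)(F)F)cc(C(F)(F)F)c4)c3)cc2-c2ccncc2)c1`, has not yet been measured in this assay. It differs from compound 3 in one place: methyl in place of hydrogen on an oxygen on an aromatic ring. Put another way, a hydroxy becomes a methoxy, so the 3-chloro-5-hydroxyphenyl of compound 3 becomes the 3-chloro-5-methoxyphenyl already found in compound 2.

Going by the values given here, no single-change step from a measured pair covers this change. A step of the size a number 9.7 percentage points higher from compound 3 to compound 4 (within the scatter) is expected, towards a higher number, resting on the fact that compound 2, which also carries the methoxy, gave 65.9%. For compound 4 in this assay a value near 60% is estimated, with a likely range from 40% to 80%.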

Compound 4, a percentage reported as activity, at one concentration (the size of the read-out at that concentration, not a potency): 69.8%
Compound 4: the middle estimate sits 9.8 percentage points below what was measured; the range from low to high includes it.
By their numbers in this assay, from the lowest: compound 1; then compound 3; then compounds 2 and 4 (each within the scatter of the next).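

In this assay, the change at this oxygen can now be read on its own, with the rest of the molecule held the same: a number 19.5 percentage points higher from compound 3 to compound 4 (beyond the scatter), so the methoxy gives a weaker effect than the hydroxy at the concentration tested. A second single change, trifluoromethyl in place of hydrogen on an aromatic carbon, gives a number 3.9 percentage points higher from compound 2 to compound 4 (within the scatter), so with the methoxy in place, this added group shows no measurable change in the reading. Nothing measured here explains why methyl on the oxygen shifts the reading.

For the compounds shown here, the hydroxy to methoxy change is seen in only one matched pair, so it remains open whether the same step would appear on the other side chain of compound 1, or whether the added trifluoromethyl would matter with a hydroxy in place of the methoxy. Also open, as far as these compounds go, is how other groups at this place would read, such as an ethoxy, which has a longer chain on the oxygen, or an amine in place of the hydroxy.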